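This account rests on a few compounds, and the source may have more. Where it says the series, first, only, none or still open, it means among the compounds named here.

Of the compounds shown here, three share one vinyl sulfone core and have been measured in an assay on U2OS cells for activation of nuclear factor erythroid 2-related factor 2 (Homo sapiens), read by chemiluminescence, with a stated time of 6 h; on this read-out lower numbers stand for an effect already at smaller amounts and higher numbers for an effect only at larger amounts of compound. Compound 1 `COc1ccccc1/C=C/S(=O)(=O)c1ccccn1` gives 7020 nM in this assay. Compound 2 `O=S(=O)(/C=C/c1ccccc1F)c1ccccn1` gives 1010 nM in this assay, and compound 3 `O=S(=O)(/C=C/c1ccccc1F)c1ncccc1C(F)(F)F` gives 124 nM. Compound 2 therefore stands second highest of the three numbers, clearly apart from both neighbours: the step of a 7.0-fold lower number from compound 1 to compound 2 (0.84 log units; beyond the scatter) put fluoro in place of methoxy on an aromatic carbon, and the step of an 8.1-fold lower number from compound 2 to compound 3 (0.91 log units; beyond the scatter) put trifluoromethyl in place of hydrogen on an aromatic carbon.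

Compound 4 `O=S(=O)(/C=C/c1ccccc1F)c1ccncc1` has not yet been measured. It keeps every atom of compound 2 but joins them differently: pyridin-4-yl in place of pyridin-2-yl on a sulfonyl sulfur whose other neighbour is a double-bonded chain carbon. Neither measured step bears directly on this change, since both altered a substituent while leaving the way the rings are joined untouched. Among the measured compounds shown here, the two steps show only that single changes around compound 2 have shifted the number beyond the scatter, in both directions. For the measured compounds named here, with no direct precedent, the step expected from compound 2 to compound 4 is a 2.0-fold higher number from compound 2 to compound 4 (0.30 log units; within the scatter), a shift that may still fall within the scatter. Compound 4 is therefore estimated at 2000 nM, with a range from 500 nM to 10000 nM.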

Compound 4, half-maximal effective concentration: 350 nM
The estimate for compound 4 lay 5.7-fold (0.76 log units) above the measured number; measured number outside the range, below it.
By their numbers in this assay, from the lowest: compound 3; then compound 4; then compound 2; then compound 1.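

In this assay, pyridin-4-yl in place of pyridin-2-yl on the sulfonyl sulfur gives a 2.9-fold lower number from compound 2 to compound 4 (0.46 log units; beyond the scatter) and so moves the number beyond the usual scatter of the measurement. The earlier steps shown here each exchanged one substituent for another on an aromatic carbon, whereas here the leaving and entering groups have the same heavy atoms, the same ring size and the same counts of hydrogen-bond donors and acceptors, so the way the ring is joined to the sulfonyl sulfur is enough by itself to change the result. No measurement at hand explains why this rearrangement of the same atoms lowers the number.

The compounds shown leave open whether the lower number seen with trifluoromethyl on the pyridin-2-yl compound would also appear if trifluoromethyl were added to the pyridin-4-yl ring of compound 4. They also leave open how the number would respond to other groups on the sulfonyl sulfur, such as a plain phenyl ring or a pyrimidine ring, and so how much of the result depends on the ring nitrogen at all.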